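Two Chalcone Pairs at the Assay Ceiling

The compounds below may be only part of what the source reports. "The series", "measured", "known", "first", "only" and "open" are said of these compounds alone.

The series rests on a chalcone frame carrying a hydroxyphenyl ring on the carbonyl carbon and a fluorinated aryl ring at the far end of the alkene. Compound 1 `O=C(/C=C/c1ccccc1C(F)(F)F)c1cccc(O)c1` places the hydroxyl in the 3-position and a trifluoromethyl group on the other ring. In a functional assay on RAW264.7 cells (Mus musculus) for inhibition, read by fluorescence, with stated times of 1 h, 24 h and 30 min (on this read-out higher numbers stand for weaker inhibition and lower numbers for stronger inhibition), compound 1 reaches only the limit > 10000 nM. Compound 2 `O=C(/C=C/c1ccccc1C(F)(F)F)c1ccc(O)cc1` differs by 4-hydroxyphenyl in place of 3-hydroxyphenyl on a carbonyl carbon. In this assay compound 2 likewise stops at the limit > 10000 nM. The step that the two limits leave unreadable from compound 1 to compound 2 therefore cannot be read, as both ends are limits.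

Compound 3 `O=C(/C=C/c1ccc(OC(F)(F)F)cc1)c1cccc(O)c1` carries a trifluoromethoxy group instead and keeps the 3-hydroxyphenyl ring; how its core differs from that of compound 1 is not broken down here. In this assay compound 3 also gives the limit > 10000 nM. All three measured values sit at the limit of > 10000 nM in this assay, at which 3 of the 3 values shown sit.

Compound 4 `O=C(/C=C/c1ccc(OC(F)(F)F)cc1)c1ccc(O)cc1` has not yet been measured. It differs from compound 3 by 4-hydroxyphenyl in place of 3-hydroxyphenyl on a carbonyl carbon, the same change that separates compound 1 from compound 2, with the same surroundings at the carbonyl carbon. Given that the step from compound 1 to compound 2 stayed within the limit, the expected step for compound 4 is a step that the limit leaves unreadable from compound 3 to compound 4, meaning little movement. Compound 4 is thus estimated at 20000 nM, most likely again reported as a limit, with an expected range from 8000 nM to 60000 nM.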

Compound 4, half-maximal inhibitory concentration: > 10000 nM
Compound 4: a limit, no number (the forecaster's own chance of this, stated with the estimate: 85%); the middle value lies beyond the limit too.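

In this assay compound 4 gives > 10000 nM, which is a limit and not a number. With compound 3 also ending in a limit, no size can be read for the change to compound 4. The compounds shown leave open whether 3-hydroxyphenyl and 4-hydroxyphenyl differ at all in inhibition, and whether any such chalcone gives a readable value: the limit of > 10000 nM in this assay, at which 4 of the 4 values shown sit.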